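Removing a Fluorine From a Poorly Soluble Amide

The source may hold more compounds than are shown below. What is called first, only, known or untested is meant among the compounds shown, and "the series" means these compounds.

Three close analogues share one core. Compound 1 `O=C(CCc1ccc2[nH]c(-c3ccc(Cl)s3)nc2c1)Nc1ccc(N2CCOCC2=O)c(Cl)c1`, compound 2 `Cc1cc(NC(=O)CCc2ccc3[nH]c(-c4ccc(Cl)s4)nc3c2)ccc1N1CCOCC1=O` and compound 3 `O=C(CCc1ccc2[nH]c(-c3ccc(Cl)s3)nc2c1)Nc1ccc(N2CCOCC2=O)cc1F` were all tested in a physicochemical assay for solubility, in phosphate buffer, at pH 7.0; on this read-out higher numbers stand for higher solubility and lower numbers for lower solubility. For compound 1 the result is a limit of the assay, < 10 ug/mL. For compound 2 the result is likewise a limit, < 10 ug/mL. For compound 3 only a limit is known as well, < 10 ug/mL. Going by the values given here, the single measured step, a step that the two limits leave unreadable from compound 1 to compound 2, cannot be sized because both of its values sit at the limit of < 10 ug/mL in this assay, at which 3 of the 3 values shown sit. Compound 4 `O=C(CCc1ccc2[nH]c(-c3ccc(Cl)s3)nc2c1)Nc1ccc(N2CCOCC2=O)cc1` differs from compound 3 by hydrogen in place of fluoro on an aromatic carbon. Among the compounds with values here, no measured step bears on this change, and with every known value resting at the limit, compound 4 is expected to stay there, the expected step being a step that the limit leaves unreadable from compound 3 to compound 4. The estimate for compound 4 is 5 ug/mL, within 1 ug/mL to 12 ug/mL.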

Compound 4, solubility: < 10 ug/mL
Compound 4: a limit, no number (the forecaster's own chance of this, stated with the estimate: 85%); the middle value is on the limit's open side.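

In this assay compound 4 gives < 10 ug/mL, a limit of the assay, so its steps from compound 1, compound 2 and compound 3 cannot be read: the limit of < 10 ug/mL in this assay, at which 4 of the 4 values shown sit.

The compounds shown leave open whether these four analogues differ at all in this assay.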